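The source may hold more compounds than are shown below. What is called first, only, known or untested is meant among the compounds shown, and "the series" means these compounds.

Measured so far in a functional assay on C6 cells (Rattus norvegicus) for cytotoxicity, read by MTT assay, with a stated time of 24 h; a lower number here means a stronger inhibitor, a higher number a weaker inhibitor:
Compound 1, `Cc1ccc2oc(-c3ccc(NC(=O)CN4CCN(CCCN(C)C)CC4)c(C)c3)nc2c1`, gives 7320 nM.
Compound 2, `Cc1ccc2oc(-c3ccc(NC(=O)CN4CCN(CCN(C)C)CC4)c(C)c3)nc2c1`, gives 16700 nM.

Among these two numbers compound 1 stands lowest; compound 2 lies a 2.3-fold higher number from compound 1 to compound 2 (0.36 log units; beyond the scatter). Among the measured compounds shown here, that single step concerns the chain carrying the dimethylamino group and is the only comparison available.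

Compound 3, `Cc1cc(-c2nc3ccccc3o2)ccc1NC(=O)CN1CCN(CCCN(C)C)CC1`, has not yet been tested in this assay. It differs from compound 1 in one place: hydrogen in place of methyl on an aromatic carbon. Cut one bond further out, the change reads 5-methyl-1,3-benzoxazol-2-yl to 1,3-benzoxazol-2-yl.

For the measured compounds named here, no measured pair touches this part of the molecule; the step from compound 1 to compound 2 alters the chain, not the fused ring, and so says nothing direct about removing this methyl. Without a comparison, the safest expectation is a small shift, with the remaining uncertainty wide. The step from compound 1 to compound 3 is therefore expected to stay within the scatter, a 1.2-fold higher number from compound 1 to compound 3 (0.09 log units; within the scatter), leaning toward a slightly higher number. Compound 3 is thus estimated at 9000 nM, within a range from 4000 nM to 20000 nM.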

Compound 3, half-maximal inhibitory concentration: 38700 nM
Beside the measured number, compound 3's estimate is 4.3-fold (0.63 log units) below it, and the stated range ends below it.
By their numbers in this assay, from the lowest: compound 1; then compound 2; then compound 3.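

In this assay, the change from 5-methyl-1,3-benzoxazol-2-yl to 1,3-benzoxazol-2-yl gives a 5.3-fold higher number from compound 1 to compound 3 (0.72 log units; beyond the scatter), so losing this one carbon makes the compound a clearly weaker inhibitor. Among the compounds shown here, the only earlier step, a 2.3-fold higher number from compound 1 to compound 2 (0.36 log units; beyond the scatter), lay in the chain, so this is the first sign that the methyl on the aromatic carbon also matters, and both steps lie beyond the scatter. Nothing available explains why this methyl makes a difference to the number.

The compounds shown leave open whether ethyl, methoxy or a chlorine atom on the same aromatic carbon would bring the number lower still, or whether the gain belongs to methyl alone. They also leave open whether taking away the methyl would cost as much in compound 2, which carries the shorter chain, since the two changes have so far been seen only one at a time, each starting from compound 1.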